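The compounds below may be only part of what the source reports. "The series", "measured", "known", "first", "only" and "open" are said of these compounds alone.

In a functional assay on A549 cells (Homo sapiens) for antiproliferative activity, read by MTT assay, with a stated time of 72 h (on this read-out lower numbers stand for stronger inhibition and higher numbers for weaker inhibition), compound 1 `O=[N+]([O-])c1ccc(COc2ccc(Nc3ncnc4cc5c(cc34)OCCOCCO5)cc2)cc1` gives 8620 nM. Compound 2 `c1ccc(COc2ccccc2Nc2ncnc3cc4c(cc23)OCCOCCOCCO4)cc1` gives 6940 nM, and the two values lie within the scatter of each other. Among the compounds with values here, compound 3 `FC(F)(F)c1ccc(COc2ccccc2Nc2ncnc3cc4c(cc23)OCCOCCO4)cc1`, which carries a 4-(trifluoromethyl)benzyl group, gives > 100000 nM, a limit of the assay and not a number, and as the only reading for a compound with that group it tilts the expectation towards weaker inhibition.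

Compound 4 `FC(F)(F)c1ccc(COc2ccc(Nc3ncnc4cc5c(cc34)OCCOCCO5)cc2)cc1` keeps the rest of compound 1 but has trifluoromethyl in place of nitro on an aromatic carbon, para to a large group: trifluoromethyl in place of nitro on an aromatic carbon. Within the data shown here, it has not yet been measured, and no step between measured compounds shows what this exchange does. A moderate move towards weaker inhibition is expected, the estimated change being a 1.7-fold higher number from compound 1 to compound 4 (0.24 log units; within the scatter). For compound 4 the expected value is 15000 nM, with an estimated range of 4000 nM to 60000 nM.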

Compound 4, half-maximal inhibitory concentration: > 100000 nM
Compound 4: a limit, no number; the forecaster's own chance of this, stated with the estimate: 20%; middle value at least 6.6-fold (0.82 log units) from the limit.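

In this assay, within the data shown here, trifluoromethyl in place of nitro on an aromatic carbon, para to a large group, gives an at least 11-fold higher number from compound 1 to compound 4 (1.06 log units; beyond the scatter), the first step to show that the group at this place can move the read-out beyond the scatter. The reading of compound 4 is a limit of the assay and not a number, so the step gives only the smallest possible size of the change. The 4-(trifluoromethyl)benzyl group now stands in two compounds, compound 3 and compound 4, and both readings are that same limit: the limit of > 100000 nM in this assay, at which 2 of the 4 values shown sit.

The compounds shown leave open whether the loss belongs to trifluoromethyl itself or whether nitro is the exception; an amine, a nitrile or plain hydrogen at this place would separate the two. They also leave open how far the same exchange carries to a longer chain in the core.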